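Thioether variants on the shared core: cytotoxicity notes

The source may report more compounds than this note shows. Statements on the series, on what has been measured and on what is new or still open speak of the compounds shown alone.

Compound 3 `CCCc1nnc(SCc2ccccc2)n1N1C(=O)c2ccccc2C1=O` gives only a limit in a functional assay on HepG2 cells (Homo sapiens) for cytotoxicity, read by MTT assay, with a stated time of 48 h (a lower number here means a stronger inhibitor, a higher number a weaker inhibitor), namely > 200000 nM. Compound 2 `C=CCSc1nnc(CCC)n1N1C(=O)c2ccccc2C1=O` likewise reaches only a limit in this assay, > 200000 nM. Compound 1 `Cc1ccc(C(=O)CSc2nnc(C)n2N2C(=O)c3ccccc3C2=O)cc1` also sits at a limit, > 200000 nM. The step that the two limits leave unreadable from compound 2 to compound 3 is thus unreadable, and the limit of > 200000 nM in this assay, at which 3 of the 3 values shown sit, covers every value in hand. Compound 4 `CCCc1nnc(SCC(=O)c2ccc(C)cc2)n1N1C(=O)c2ccccc2C1=O` differs from compound 3 by (4-methylphenyl)carbonyl in place of phenyl on a saturated chain carbon bound to a sulfur. Compound 1 carries the same ((4-methylphenyl)carbonyl)methyl thioether and shows only its limit > 200000 nM. Among the compounds with values here, no measured step has a readable size, so no shift beyond the scatter is expected; the estimated step that the limit leaves unreadable from compound 3 to compound 4 is none. For compound 4 the expected value is 300000 nM, spanning 150000 nM to 1000000 nM, most probably again reported only as a limit.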

Compound 4, half-maximal inhibitory concentration: > 200000 nM
Compound 4 was reported as a limit; the forecaster's own chance of this, stated with the estimate: 85%; the middle value lies beyond the limit too.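

Compound 4 also gives only a limit, > 200000 nM, so its steps from compound 1, compound 2 and compound 3 cannot be read. The compounds shown leave open whether any thioether change on the shared core alters cytotoxicity in this assay: the limit of > 200000 nM in this assay, at which 4 of the 4 values shown sit.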